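The compounds below may be only part of what the source reports. "The series", "measured", "known", "first", "only" and "open" are said of these compounds alone.

Measured compounds:
- compound 1, `CCCCCCCCNc1cncc(C(N)=O)n1`: 161000 nM
- compound 2, `CCCCCCCCNc1cnc(C(N)=O)cn1`: > 250000 nM

In an ADME assay on HepG2 cells (Homo sapiens) for cytotoxicity, with a stated time of 24 h (a lower number here means a stronger inhibitor, a higher number a weaker inhibitor), compound 1 gives 161000 nM. Compound 2 gives only a limit of the assay, > 250000 nM, which is the limit of > 250000 nM in this assay, at which 1 of the 2 values shown sits; its true value is not known as a number. Compound 3, `CCCCCCCNc1cnc(C(N)=O)cn1`, has not yet been measured in this assay. It differs from compound 2 by hydrogen in place of methyl on a saturated chain carbon, seven bonds along the chain from a nitrogen on an aromatic ring. Among the measured compounds shown here, no measured pair shows the effect of such a change here, so the expectation rests only on where compound 2 stands. Because compound 2 sits at the limit of > 250000 nM in this assay, at which 1 of the 2 values shown sits, compound 3 is expected to remain weak in this assay, with an expected step of a number no higher from compound 2 to compound 3 (the limit leaves the size open) that does not go beyond the scatter. For compound 3 the estimate is 250000 nM, ranging from 100000 nM to 600000 nM, and it is expected that the assay may again report only a limit.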

Compound 3, half-maximal inhibitory concentration: > 250000 nM
Compound 3 ended at the assay's limit; the forecaster's own chance of this, stated with the estimate: 70%; the middle value lies on the limit itself.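

No step can be read between compound 2 and compound 3 in this assay, since each gives only a limit of the assay: the limit of > 250000 nM in this assay, at which 2 of the 3 values shown sit. The compounds shown leave open whether hydrogen in place of methyl on that saturated chain carbon changes the true value at all.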